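Lengthening the Nitrile Chain: From Compound 3 to Compound 4

The compounds below may be only part of what the source reports. "The series", "measured", "known", "first", "only" and "open" are said of these compounds alone.

Measured so far:
Compound 1 `CCc1cc(C(C)=O)c(O)cc1OCCCCCCC#N`: 103%
Compound 2 `C=CCc1cc(C(C)=O)c(O)cc1OCC#N`: 20%
Compound 3 `C=CCc1cc(C(C)=O)c(O)cc1OCCCCC#N`: 92%

These three compounds share one core and were examined in an assay on isolated protein for inhibition of leukotriene B4 receptor 1 (Homo sapiens), tested at 10 uM; a higher number here means more inhibition at the concentration tested (going by the name of the read-out), a lower number less inhibition. Compound 3 stands second of the three numbers: compound 1 lies higher by a margin beyond the scatter, while compound 2 lies far below it.

Compound 4 `C=CCc1cc(C(C)=O)c(O)cc1OCCCCCCC#N` has not yet been tested in this assay. It arises from compound 3 by one change: 2-cyanoethyl in place of cyano on a saturated chain carbon, four bonds along the chain from an oxygen on an aromatic ring. The entering group brings four heavy atoms where the leaving group had two, so the chain grows while the nitrile at its end stays.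

Among the compounds with values here, one measured step bears directly on this. Between compound 2 and compound 3 the same kind of lengthening occurred, and the result was a number 72 percentage points higher from compound 2 to compound 3 (beyond the scatter). Compound 1 also gives 103% and differs from compound 4 only elsewhere in the structure. Both observations point the same way: the longer chains go with the higher numbers in this assay, and the number for compound 3 is already high. The expected step is therefore a number 8 percentage points higher from compound 3 to compound 4 (within the scatter), small and within the scatter. Compound 4 is estimated at 100%, with a range from 88% to 110%.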

Compound 4, a percentage reported as inhibition, at one concentration (the size of the read-out at that concentration, not a potency): 97%
For compound 4 the middle estimate is 3 percentage points above the measured one, within the range that was stated.
By their numbers in this assay, from the lowest: compound 2; then compounds 3, 4 and 1 (each within the scatter of the next, the first and the last beyond it).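

In this assay, 2-cyanoethyl in place of cyano, four bonds along the chain from an oxygen on an aromatic ring, gives a number 5 percentage points higher from compound 3 to compound 4 (within the scatter), so this further lengthening brings no change that can be told from the scatter. The large gain over the full extension (5-cyanopentyl in place of cyano on a saturated chain carbon bound to an oxygen on an aromatic ring, a number 77 percentage points higher from compound 2 to compound 4 (beyond the scatter)) therefore comes with the first lengthening, and the number then holds level across the two longer chains shown. With the long chain in place, vinyl in place of methyl on a saturated chain carbon bound to an aromatic carbon gives a number 6 percentage points lower from compound 1 to compound 4 (within the scatter), so this change elsewhere in the structure also cannot be told from the scatter at this one tested concentration.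

Nothing available here explains why the shortest chain gives so much less inhibition than the longer ones. On these data alone, it remains open whether a still longer chain would hold the number, and whether an amine or a carboxylic acid in place of the nitrile would do the same.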